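The source may report more compounds than this note shows. Statements on the series, on what has been measured and on what is new or still open speak of the compounds shown alone.

Working notes on the series.

Compound 3 `COc1cc2nccc(Oc3ccc(NC(=O)c4cc(-c5ccc(F)cc5)on4)cc3)c2cc1OC` is the reference here. In a functional assay on PC-3 cells (Homo sapiens) for antiproliferative activity, read by MTT assay, with a stated time of 72 h (on this read-out lower numbers stand for stronger inhibition and higher numbers for weaker inhibition), compound 3 gives 29400 nM, the highest of the two numbers measured in this series. Compound 1 `COc1cc2c(Oc3ccc(NC(=O)c4nc(-c5ccc(F)cc5)no4)cc3)ccnc2cc1OCCCN1CCC(C)CC1` gives 1040 nM in this assay, a lower number than compound 3 beyond the scatter. Compound 2 `COc1cc2nccc(Oc3ccc(NC(=O)c4nnc(-c5ccc(F)cc5)o4)cc3)c2cc1OC` gives only a limit of the assay, > 100000 nM. Going by the values given here, the one single-place step measured is an at least 3.4-fold lower number from compound 2 to compound 3 (0.53 log units; beyond the scatter), and the limit at which compound 2 sits, (the limit of > 100000 nM in this assay, at which 1 of the 3 values shown sits), means that its true size is open upward.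

Compound 4 `COc1cc2nccc(Oc3ccc(NC(=O)c4nc(-c5ccc(F)cc5)no4)cc3)c2cc1OC` is not yet measured. Against compound 3 the change is 3-(4-fluorophenyl)-1,2,4-oxadiazol-5-yl in place of 5-(4-fluorophenyl)-1,2-oxazol-3-yl on a carbonyl carbon. Among the compounds with values here, no measured step covers exactly this exchange. The step from compound 2 to compound 3 shows that swapping one five-membered heteroaryl for another at the carbonyl carbon can move the number beyond the scatter, and compound 1, which carries the same 3-(4-fluorophenyl)-1,2,4-oxadiazol-5-yl group but differs elsewhere, gives a lower number than compound 3. A moderate move toward a lower number is therefore expected for compound 4, though a step of no more than the scatter cannot be excluded. The expected step is a 2.5-fold lower number from compound 3 to compound 4 (0.39 log units; beyond the scatter). Compound 4 is estimated at 12000 nM in this assay, within 2500 nM to 70000 nM.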

Compound 4, half-maximal inhibitory concentration: > 100000 nM
Compound 4: a limit, no number (the forecaster's own chance of this, stated with the estimate: 12%); middle value at least 8.3-fold (0.92 log units) away from the limit.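

Putting 3-(4-fluorophenyl)-1,2,4-oxadiazol-5-yl in place of 5-(4-fluorophenyl)-1,2-oxazol-3-yl on the carbonyl carbon gives in this assay an at least 3.4-fold higher number from compound 3 to compound 4 (0.53 log units; beyond the scatter) as a step beyond the scatter, and compound 4 stands at a limit of the assay, so the size of this step is open upward. With the 3-(4-fluorophenyl)-1,2,4-oxadiazol-5-yl group held constant, hydrogen in place of 2-(4-methylpiperidin-1-yl)ethyl gives an at least 96-fold higher number from compound 1 to compound 4 (1.98 log units; beyond the scatter) as a large step, so the lower number of compound 1 cannot be credited to that heteroaryl group alone and goes with the 2-(4-methylpiperidin-1-yl)ethyl chain on the oxygen. The step between compound 2 and compound 4 cannot be read, and the 1,3,4-oxadiazole and 1,2,4-oxadiazole groups cannot be ordered against each other: the limit of > 100000 nM in this assay, at which 2 of the 4 values shown sit.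

From the compounds shown here alone, it remains open whether the 2-(4-methylpiperidin-1-yl)ethyl chain would lower the number to a similar extent with 5-(4-fluorophenyl)-1,2-oxazol-3-yl on the carbonyl carbon. Also open, going by these compounds, is whether a shorter chain, or a chain ending in morpholine or a primary amine, would serve in the same way.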